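Methylsulfanyl for triazolyl on an orexin receptor antagonist

The source may hold more compounds than are shown below. What is called first, only, known or untested is meant among the compounds shown, and "the series" means these compounds.

Compound 1 `COc1ccc(C(=O)N2C[C@H](Oc3nccc(C#N)c3C)CC[C@H]2C)c(-n2nccn2)n1` is one of two compounds assessed in a functional assay on cells for antagonist activity at Orexin/Hypocretin receptor type 1 (Homo sapiens), read by FLIPR and calcium flux; a lower number here means a stronger inhibitor, a higher number a weaker inhibitor. In this assay compound 1 gives 5930 nM, the higher of the two numbers. Compound 2 `Cc1c(C#N)ccnc1O[C@@H]1CC[C@@H](C)N(C(=O)c2ccccc2C(F)(F)F)C1` gives 4960 nM in this assay, which lies within the scatter of the number for compound 1, so the two cannot be told apart.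

Compound 3 `COc1ccc(C(=O)N2C[C@H](Oc3nccc(C#N)c3C)CC[C@H]2C)c(SC)n1` has not been measured. It differs from compound 1 by methylsulfanyl in place of 2H-1,2,3-triazol-2-yl on an aromatic carbon. Going by the values given here, no measured pair shows this change, so its effect can only be estimated. The two measured compounds, though they differ at several places, give numbers within the scatter of each other, which offers little ground to expect a large shift.

Compound 3 is therefore expected to give about 7500 nM in this assay, with a likely range from 2000 nM to 25000 nM. The step of a 1.3-fold higher number from compound 1 to compound 3 (0.10 log units; within the scatter) is expected to be small, tending if anything toward a weaker inhibitor.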

Compound 3, half-maximal inhibitory concentration: > 10000 nM
Compound 3: a limit, no number; the forecaster's own chance of this, stated with the estimate: 15%; middle value at least 1.3-fold (0.12 log units) away from the limit.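

In this assay compound 3 gives > 10000 nM, which is a limit of the assay and not a number. Going by these compounds alone, the pair gives the first direct reading at this position, on an aromatic carbon next to the ring nitrogen: methylsulfanyl in place of 2H-1,2,3-triazol-2-yl gives an at least 1.6-fold higher number from compound 1 to compound 3 (0.22 log units; that floor lies within the scatter), so the change shows no gain in inhibition, while its floor alone does not separate the two compounds. The full size of the step cannot be read because the reading ends at a limit: the limit of > 10000 nM in this assay, at which 1 of the 3 values shown sits.

The compounds shown leave open whether another group at this place, such as an amine or a pyrazolyl ring, would give a lower number than the triazolyl of compound 1. They also leave open whether methylsulfanyl would act the same way on a different core.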